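Side-chain variation on a shared core, cytotoxicity series

The source may report more compounds than this note shows. Statements on the series, on what has been measured and on what is new or still open speak of the compounds shown alone.

Measured so far:
compound 1, `CCCCCCc1c(F)c(N)c2c(=O)cc(-c3ccc(N)c(F)c3)oc2c1F`: in a functional assay on MCF7 cells (Homo sapiens) for cytotoxicity, read by neutral red uptake, with a stated time of 3 days (on this read-out lower numbers stand for stronger inhibition and higher numbers for weaker inhibition), compound 1 gives only a limit, > 10000 nM.
compound 2, `[N-]=[N+]=Nc1c(F)c(N)c2c(=O)cc(-c3ccc(N)c(F)c3)oc2c1F`: in this assay compound 2 gives 460 nM.
compound 3, `CCCCCC(=O)OCc1c(F)c(N)c2c(=O)cc(-c3ccc(N)c(F)c3)oc2c1F`: in this assay compound 3 gives 160 nM.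

Compound 3 stands lowest of the two numbers; its nearest neighbour is compound 2, with a 2.9-fold lower number from compound 2 to compound 3 (0.46 log units; beyond the scatter). Compound 1 sits at the limit of > 10000 nM in this assay, at which 1 of the 3 values shown sits, so an at least 21-fold lower number from compound 1 to compound 2 (1.33 log units; beyond the scatter) and an at least 62-fold lower number from compound 1 to compound 3 (1.79 log units; beyond the scatter) are large but open-ended.

Compound 4, `CN(C)CCCOCc1c(F)c(N)c2c(=O)cc(-c3ccc(N)c(F)c3)oc2c1F`, differs from compound 3 by 3-(dimethylamino)propyl in place of pentylcarbonyl on an oxygen on a saturated carbon. For the measured compounds named here, no measured step changes this group on the oxygen; the closest comparison is the swap of the whole side group, a 2.9-fold lower number from compound 2 to compound 3 (0.46 log units; beyond the scatter), a modest step. A change of modest size in this assay, direction uncertain, is therefore expected: compound 4 is estimated at 300 nM, range 60 nM to 1500 nM. This estimate corresponds to an expected 1.9-fold higher number from compound 3 to compound 4 (0.27 log units; within the scatter).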

Compound 4, half-maximal inhibitory concentration: > 10000 nM
Compound 4: no number, only a limit; the forecaster's own chance of this, stated with the estimate: 10%; middle value at least 33-fold (1.52 log units) from the limit.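

In this assay, an oxygen on the saturated carbon does not by itself keep the low number: 3-(dimethylamino)propyl in place of pentylcarbonyl gives an at least 62-fold higher number from compound 3 to compound 4 (1.79 log units; beyond the scatter), and the comparison with azido gives an at least 21-fold higher number from compound 2 to compound 4 (1.33 log units; beyond the scatter). Compound 4 gives only a limit, not a number, as does compound 1: the limit of > 10000 nM in this assay, at which 2 of the 4 values shown sit.
The step between compound 1 and compound 4 cannot be read.

The compounds shown leave open whether the change follows from losing the carbonyl or from gaining the dimethylamino end. A pentyl ether on this oxygen, or an ester carrying a dimethylamino chain, would separate the two.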